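The source may hold more compounds than are shown below. What is called first, only, known or untested is meant among the compounds shown, and "the series" means these compounds.

Measured so far:
compound 1, `O=C1C(NC2CC2)=CC(=O)c2c1nc1n2[C@H]2OC[C@@H](O)[C@H]2OC1`: > 4000 nM
compound 2, `O=C1C=C(NCc2ccccc2)C(=O)c2c1nc1n2[C@H]2OC[C@@H](O)[C@H]2OC1`: 2670 nM

In a functional assay on MGC-803 cells (Homo sapiens) for inhibition, read by sulforhodamine B assay (on this read-out higher numbers stand for weaker inhibition and lower numbers for stronger inhibition), compound 1 gives only a limit, > 4000 nM, and no number. Compound 2 gives a number in this assay, 2670 nM. Among the two values shown, one sits at a limit (the limit of > 4000 nM in this assay, at which 1 of the 2 values shown sits). Compound 3, `CCc1ccc(NC2=CC(=O)c3c(nc4n3[C@H]3OC[C@@H](O)[C@H]3OC4)C2=O)cc1`, has not yet been measured in this assay. It differs from compound 1 in one place: 4-ethylphenyl in place of cyclopropyl on an amine nitrogen. Going by the values given here, no step between two measured compounds is available here, so the size of this step can only be estimated. Among the compounds with values here, the step is expected to run toward stronger inhibition by an amount somewhat beyond the scatter, as compound 2, the only compound with a number, reaches 2670 nM. The expected step is an at least 1.6-fold lower number from compound 1 to compound 3 (0.20 log units; that floor lies within the scatter). Compound 3 is therefore estimated at 2500 nM in this assay, within 800 nM to 8000 nM.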

Compound 3, half-maximal inhibitory concentration: 1110 nM
Beside the measured number, compound 3's estimate is 2.3-fold (0.35 log units) above it, within the range that was stated.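

In this assay, the amine nitrogen on the double-bonded ring carbon of the shared core turns out to be a place where the substituent matters: 4-ethylphenyl in place of cyclopropyl gives an at least 3.6-fold lower number from compound 1 to compound 3 (0.55 log units; beyond the scatter). The earlier compounds shown here offered no step at all, and this one shows that a larger aromatic group is tolerated here and goes with stronger inhibition. Its full size stays unknown, and the step can be given only as a floor, because compound 1 sits at a limit rather than a number: the limit of > 4000 nM in this assay, at which 1 of the 3 values shown sits.

The compounds shown leave open whether the change follows from the aromatic ring itself or from the ethyl group on it, as plain phenyl or a longer alkyl chain would help to tell. They also leave open how a 4-methoxyphenyl or 4-chlorophenyl on this amine nitrogen would read.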